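Opening a ring on the core of compound 1

The compounds below may be only part of what the source reports. "The series", "measured", "known", "first", "only" and "open" are said of these compounds alone.

Compound 1 `CC(C)c1noc(N2CCC(Oc3cc(N4CCc5cc(N6CCCNS6(=O)=O)ccc54)ncn3)CC2)n1` was tested in an assay on CHO cells for agonist activity at Glucose-dependent insulinotropic receptor (Homo sapiens), read by a luciferase reporter and cAMP accumulation, with a stated time of 2 h (a higher number here means that more compound is needed for the effect, a lower number that less compound is needed), and gives 24 nM. Among the two compounds with a single number it stands lowest. Its nearest neighbour is compound 2 `CC(C)c1noc(N2CCC(Oc3cc(N4CCc5cc(N6CC(O)CCC6=O)ccc54)ncn3)CC2)n1`, which in this assay gives 90 nM; the step of a 3.8-fold higher number from compound 1 to compound 2 (0.57 log units; beyond the scatter) exchanges one six-membered ring for another on the same aromatic carbon. Compound 3 `CC(C)SC(=O)N1CCC(Oc2cc(N3CCc4cc([S+]([O-])CCO)ccc43)ncn2)CC1` has been measured more than once in this assay and gives 14 nM; 57 nM; 9.7 nM (3 entries); the spread across its entries the several entries of compound 3 in this assay, 14 nM; 57 nM; 9.7 nM (3 entries) shows how far repeated measurements of one compound can wander.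

Compound 4 `CC(=O)N(C)c1ccc2c(c1)CCN2c1cc(OC2CCN(c3nc(C(C)C)no3)CC2)ncn1` differs from compound 1 in a single place: a group of 5 heavy atoms (3 carbon, 1 nitrogen, 1 oxygen; no ring) in place of a group of 8 heavy atoms (3 carbon, 2 nitrogen, 2 oxygen, 1 sulfur; one six-membered non-aromatic ring with 3 hetero atoms), on an aromatic carbon. Among the compounds with values here, the only measured step that bears on this change is the one from compound 1 to compound 2, where the same group left the same aromatic carbon, a different six-membered ring took its place, and the number rose modestly. Here the ring leaves altogether and an open-chain acetyl(methyl)amino group enters, so a change of similar size, in the same direction, is expected. For compound 4 the expected number in this assay is 60 nM, with a range from 20 nM to 180 nM. The estimated step of a 2.5-fold higher number from compound 1 to compound 4 (0.40 log units; beyond the scatter) is therefore a modest rise.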

Compound 4, half-maximal effective concentration: 75 nM
Compound 4: middle estimate off by 1.3-fold (0.10 log units), on the low side; measured number inside the range.
By their numbers in this assay, from the lowest: compound 1; then compounds 4 and 2 (each within the scatter of the next).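

Taking the ring away entirely still costs something at this aromatic carbon in this assay: a 3.1-fold higher number from compound 1 to compound 4 (0.49 log units; beyond the scatter). The open-chain acetyl(methyl)amino group and the 5-hydroxy-2-oxopiperidin-1-yl ring cannot be told apart, as the step of a 1.2-fold lower number from compound 2 to compound 4 (0.08 log units; within the scatter) shows, so among these three compounds a ring as such does not set the level, and only the sulfur-containing ring of compound 1 stands apart from the other two groups. That edge of compound 1 rests on a single entry, and repeated measurements of one compound can wander widely in this assay, so its size should be read with caution: the several entries of compound 3 in this assay, 14 nM; 57 nM; 9.7 nM (3 entries)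

As far as these compounds go, what remains open is whether the sulfur-containing part of that ring or the ring built around it accounts for the edge of compound 1, a question that an open-chain methanesulfonylamino group on the same aromatic carbon would address. From the compounds shown here alone, how a plain amine or a carboxylic acid at this place would compare on the core of compound 1 also stays unknown.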